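A few compounds are considered here, and "the series" means these few. Any claim that something is new, unique, unknown or untested is made for them only; others in the source may bear on it.

In a functional assay on HeLa cells (Homo sapiens) for antiproliferative activity, read by sulforhodamine B assay, with a stated time of 72 h (on this read-out lower numbers stand for stronger inhibition and higher numbers for weaker inhibition), compound 3 `Cc1ccccc1NC(=S)N/N=C/c1ccc2ccccc2n1` stands at > 100000 nM as a limit and not a number. Compound 1 `Cc1cccc(NC(=S)N/N=C/c2ccc3ccccc3n2)c1` reads > 100000 nM and this too is a limit. For the measured compounds named here, compound 2 `Cc1ccc(NC(=S)N/N=C/c2ccc3ccccc3n2)cc1` gives 86000 nM as the only actual number so far. The reference point for the series is the limit of > 100000 nM in this assay, at which 2 of the 3 values shown sit, and compound 3 is one of those values.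

Compound 4 `S=C(N/N=C/c1ccc2ccccc2n1)Nc1ccccc1Br` follows from compound 3 by 2-methylphenyl to 2-bromophenyl. The difference is bromo in place of methyl on an aromatic carbon and it is bromo in place of methyl on an aromatic carbon, ortho to a large group.

Going by the values given here, no measured step makes this exchange. The closest steps only move the methyl: an at least 1.1-fold lower number from compound 1 to compound 2 (0.06 log units; that floor lies within the scatter) and an at least 1.1-fold higher number from compound 2 to compound 3 (0.06 log units; that floor lies within the scatter) are the two readable ones, and neither floor leaves the scatter. The third is a step that the two limits leave unreadable from compound 1 to compound 3 and gives no size.

Compound 2 at 86000 nM therefore sets the expected level, with a modest move toward lower numbers at most. The expected step is an at least 1.4-fold lower number from compound 3 to compound 4 (0.15 log units; that floor lies within the scatter) and it may stay hidden behind the limit. For compound 4 the estimated value is 70000 nM with an expected range from 20000 nM to 100000 nM in this assay and a report as a limit remains quite possible.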

Compound 4, half-maximal inhibitory concentration: > 100000 nM
Compound 4 ended at the assay's limit; the forecaster's own chance of this, stated with the estimate: 45%; middle value at least 1.4-fold (0.15 log units) away from the limit.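

In this assay compound 4 gives > 100000 nM, which is a limit of the assay and not a number. For the compounds shown here, the steps from compound 3 and from compound 1 to compound 4 cannot be read, as both ends of each are limits, and the one readable step is an at least 1.1-fold higher number from compound 2 to compound 4 (0.06 log units; that floor lies within the scatter), so bromo in place of methyl at this place, on an aromatic carbon ortho to a large group, brings no measurable activity into the assay's range. The earlier compounds only moved the methyl around the ring, whereas this result extends the picture to a change of the group itself, and the series now clusters at the top of the range: the limit of > 100000 nM in this assay, at which 3 of the 4 values shown sit.

Going by these compounds alone, compound 2, at 86000 nM, remains the only actual number, so it is open whether bromo in place of the methyl of compound 2 would also give a readable value. Also open, on these data alone, is whether a different group on the same ring, such as an amine, a carboxylic acid or a methoxy group, would bring the series to readable values in this assay.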